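Replacing a dihydroxypropyl chain with an oxane ring group

The source may hold more compounds than are shown below. What is called first, only, known or untested is meant among the compounds shown, and "the series" means these compounds.

Measured in a functional assay on A549 cells (Homo sapiens) for cytotoxicity, read by MTT assay, with a stated time of 72 h; a higher number here means a weaker inhibitor, a lower number a stronger inhibitor:
- Compound 1 `O=C1c2c[n+]([O-])c3ccccc3c2C(=O)c2c1c1ccccc1n2Cc1cn([C@H]2O[C@H](CO)[C@@H](O)[C@H]2O)nn1`: 2680 nM
- Compound 2 `O=C1c2c[n+]([O-])c3ccccc3c2C(=O)c2c1c1ccccc1n2Cc1cn(CC(O)CO)nn1`: 880 nM

Compound 2 has the lower number of these two, which makes it the stronger inhibitor. Compound 3 `O=C1c2c[n+]([O-])c3ccccc3c2C(=O)c2c1c1ccccc1n2Cc1cn([C@@H]2O[C@H](CO)[C@@H](O)[C@H](O)[C@H]2O)nn1` has not yet been measured. It differs from compound 2 on an aromatic nitrogen, where 3,4,5-trihydroxy-6-(hydroxymethyl)oxan-2-yl takes the place of 2,3-dihydroxypropyl: 3,4,5-trihydroxy-6-(hydroxymethyl)oxan-2-yl in place of 2,3-dihydroxypropyl on an aromatic nitrogen. Within the data shown here, one measured step bears on this, a 3.0-fold lower number from compound 1 to compound 2 (0.48 log units; beyond the scatter), which is modest but beyond the scatter. There, 2,3-dihydroxypropyl replaced a ring group, 3,4-dihydroxy-5-(hydroxymethyl)oxolan-2-yl. The new change runs the opposite way, from chain to ring group, so a rise of similar size is expected, although a single step is thin evidence. The expected step in this assay is a 2.7-fold higher number from compound 2 to compound 3 (0.44 log units; beyond the scatter). For compound 3 the estimated value is 2400 nM, with an expected range of 1000 nM to 6000 nM.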

Compound 3, half-maximal inhibitory concentration: 560 nM
Beside the measured number, compound 3's estimate is 4.3-fold (0.63 log units) above it, outside the stated range (below it).
By their numbers in this assay, from the lowest: compounds 3 and 2 (each within the scatter of the next); then compound 1.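

In this assay, the change from chain to ring group on this aromatic nitrogen gives a result within the scatter (a 1.6-fold lower number from compound 2 to compound 3 (0.20 log units; within the scatter)), so 2,3-dihydroxypropyl and 3,4,5-trihydroxy-6-(hydroxymethyl)oxan-2-yl cannot be told apart here, although the entering group has 11 heavy atoms against 5. The two ring groups, by contrast, do separate (a 4.8-fold lower number from compound 1 to compound 3 (0.68 log units; beyond the scatter)), so among these three compounds the higher number belongs to 3,4-dihydroxy-5-(hydroxymethyl)oxolan-2-yl alone, not to ring groups in general. Nothing available explains this difference between the two ring groups.

From the compounds shown here alone, all three groups carry hydroxyl groups, so it remains open how a plain butyl chain, an amine or a carboxylic acid on this aromatic nitrogen would read. Also open, going by these compounds, is whether the stereocentres matter, as the six-membered ring appears in only one arrangement.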